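From cyclobutyl to thiophen-3-yl at the solubility limit

The compounds below may be only part of what the source reports. "The series", "measured", "known", "first", "only" and "open" are said of these compounds alone.

Compound 1 `CN1CCC(C(=O)N2Cc3c(NC(=O)C4CCC4)n[nH]c3C2(C)C)CC1`: > 225000 nM
Compound 2 `CC1(C)c2[nH]nc(NC(=O)c3ccc(F)cc3)c2CN1C(=O)C1CCN(C2CC2)CC1`: > 225000 nM

In a physicochemical assay for solubility, at pH 7 (a lower number here means a less soluble compound, a higher number a more soluble compound), compound 1 gives > 225000 nM, which is a limit and not a number. Compound 2 gives > 225000 nM, which is also a limit. The record so far is therefore only (the limit of > 225000 nM in this assay, at which 2 of the 2 values shown sit). Compound 3 `CN1CCC(C(=O)N2Cc3c(NC(=O)c4ccsc4)n[nH]c3C2(C)C)CC1` departs from compound 1 in one place, with thiophen-3-yl in place of cyclobutyl on a carbonyl carbon. Among the compounds with values here, no measured step shows what such a change does, so no step beyond the scatter is expected in this assay, and no direction can be favoured. The expected step is an at least 1.1-fold lower number from compound 1 to compound 3 (0.05 log units; that floor lies within the scatter). The estimate for compound 3 is 200000 nM, with an expected range from 100000 nM to 225000 nM.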

Compound 3, solubility: > 225000 nM
Compound 3: a limit, no number; the forecaster's own chance of this, stated with the estimate: 70%; at least 1.1-fold (0.05 log units) between middle value and limit.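

Compound 3, like compound 1, stands at a limit and not at a number, so no step between them can be read: the limit of > 225000 nM in this assay, at which 3 of the 3 values shown sit.

The compounds shown leave open whether thiophen-3-yl in place of cyclobutyl on a carbonyl carbon changes solubility at all, and in which direction.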